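Lengthening the Amine Chain of Compound 3

A few compounds are considered here, and "the series" means these few. Any claim that something is new, unique, unknown or untested is made for them only; others in the source may bear on it.

In a functional assay on PC-3 cells (Homo sapiens) for antiproliferative activity, read by WST assay, with a stated time of 3 days (a lower number here means a stronger inhibitor, a higher number a weaker inhibitor), compound 1 (`CCCCOc1c(-c2cc(OC)c(OC)c(OC)c2)oc2ccccc2c1=O`) gives 12800 nM, compound 2 (`CCCN(CCC)CCCOc1c(-c2cc(OC)c(OC)c(OC)c2)oc2ccccc2c1=O`) gives 16800 nM and compound 3 (`CCCCN(CCCC)CCCOc1c(-c2cc(OC)c(OC)c(OC)c2)oc2ccccc2c1=O`) gives 7100 nM. Compound 3 is separated from only one of the other two: the data show a 2.4-fold lower number from compound 2 to compound 3 (0.37 log units; beyond the scatter), a modest step, while a 1.8-fold lower number from compound 1 to compound 3 (0.26 log units; within the scatter) stays within the scatter, as does a 1.3-fold higher number from compound 1 to compound 2 (0.12 log units; within the scatter).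

Compound 4 (`CCCCN(CCCC)CCCCCOc1c(-c2cc(OC)c(OC)c(OC)c2)oc2ccccc2c1=O`) differs from compound 3 in one place: 2-(dibutylamino)ethyl in place of dibutylamino on a saturated chain carbon, three bonds along the chain from an oxygen on an aromatic ring. It carries 2-(dibutylamino)ethyl in place of dibutylamino on a saturated chain carbon, three bonds along the chain from an oxygen on an aromatic ring. The same difference reads as (dibutylamino)methyl to 3-(dibutylamino)propyl.

Within the data shown here, none of the measured steps alters the length of this chain, so the three steps offer only indirect guidance. All of them change the group at the end of the chain, and only one exceeds the scatter. The expectation therefore starts from compound 3 at 7100 nM and allows for little movement. The expected step is a 1.3-fold lower number from compound 3 to compound 4 (0.11 log units; within the scatter), which would not lie beyond the scatter. For compound 4 the estimated value is 5500 nM, with an expected range from 2200 nM to 14000 nM.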

Compound 4, half-maximal inhibitory concentration: 6800 nM
Beside the measured number, compound 4's estimate is 1.2-fold (0.09 log units) below it, and the stated range covers the measured number.
By their numbers in this assay, from the lowest: compounds 4, 3, 1 and 2 (each within the scatter of the next, the first and the last beyond it).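

Lengthening the link to 2-(dibutylamino)ethyl in place of dibutylamino gives a 1.0-fold lower number from compound 3 to compound 4 (0.02 log units; within the scatter) in this assay and so adds no change that this assay can separate at this position. The earlier compounds shown here varied only the group at the end of the chain, whereas this step alters the chain itself and leaves the dibutylamino end unchanged. Against the dipropylamino compound the longer chain shows a 2.5-fold lower number from compound 2 to compound 4 (0.39 log units; beyond the scatter) as a modest step, much like a 2.4-fold lower number from compound 2 to compound 3 (0.37 log units; beyond the scatter) for the shorter chain, while a 1.9-fold lower number from compound 1 to compound 4 (0.27 log units; within the scatter) keeps compound 4 no more separated from the butoxy compound than compound 3 is. No supporting data bear on why the number holds when the chain grows.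

The compounds shown leave open whether a still longer chain would also leave the number in place, or whether the flat response would end at some length. They also leave open whether the dipropylamino end would respond to the longer chain as the dibutylamino end does, and how a carboxylic acid at the end of the chain would compare.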